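A basic side chain replaces the trifluoroethyl ether

The source may report more compounds than this note shows. Statements on the series, on what has been measured and on what is new or still open speak of the compounds shown alone.

Compound 2 `CCc1cccc2c(OC)c(-c3occ(C)c3COCC(F)(F)F)ccc12` sits at the lower end of the two numbers seen so far. In a functional assay on DU-145 cells (Homo sapiens) for cytotoxicity, read by MTT assay, with a stated time of 72 h (on this read-out lower numbers stand for an effect already at smaller amounts and higher numbers for an effect only at larger amounts of compound), compound 2 gives 5.7 ug/mL. Its nearest neighbour is compound 1 `CCc1cccc2c(OC)c(-c3occ(C)c3CO)ccc12`, which in this assay gives 7.2 ug/mL. Among the measured compounds shown here, the only measured step, a 1.3-fold lower number from compound 1 to compound 2 (0.10 log units; within the scatter), lies within the scatter, so the two compounds cannot be told apart on this read-out.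

Compound 3 `CCc1cccc2c(OC)c(-c3occ(C)c3COC(=O)CCN(CC)CC)ccc12` has not yet been measured. It differs from compound 2 in one place: (2-(diethylamino)ethyl)carbonyl in place of 2,2,2-trifluoroethyl on an oxygen on a saturated carbon. For the measured compounds named here, no measured step covers this change; the step from compound 1 to compound 2 touches the same oxygen on a saturated carbon but exchanges hydrogen for 2,2,2-trifluoroethyl, and it stayed within the scatter. That single step gives no reason to expect movement beyond the scatter in this assay in either direction, though the entering group is unlike anything tested here, which keeps the expectation wide. Compound 3 is therefore expected to give 6 ug/mL, with a range from 2 ug/mL to 20 ug/mL. The change is expected to amount to a 1.1-fold higher number from compound 2 to compound 3 (0.02 log units; within the scatter).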

Compound 3, concentration for half-maximal effect: > 10 ug/mL
Compound 3 was reported as a limit; the forecaster's own chance of this, stated with the estimate: 5%; at least 1.6-fold (0.22 log units) between middle value and limit.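

In this assay compound 3 is reported only as a limit and not as a number: the limit of > 10 ug/mL in this assay, at which 1 of the 3 values shown sits.

Read as floors, the two new steps are an at least 1.7-fold higher number from compound 2 to compound 3 (0.24 log units; that floor lies within the scatter) and an at least 1.3-fold higher number from compound 1 to compound 3 (0.14 log units; that floor lies within the scatter). This is the first sign that the oxygen on a saturated carbon may not accept every group equally, since (2-(diethylamino)ethyl)carbonyl, which brings in nitrogen and a carbonyl, is the first group here to give a limit instead of a number, yet both floors lie within the scatter, so a real loss is suggested but not shown.

The compounds shown leave open how far the true value of compound 3 lies from the other two, so the size of this change remains unknown. They also do not separate the two new features of the entering group: a plain acetyl group would carry the carbonyl without the amine, while a 2-(diethylamino)ethyl group joined directly to the oxygen would carry the amine without the carbonyl, and each would show which part goes with the limit.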